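Replacing Dipropylamino with Methoxy on a Shared Core

The compounds below may be only part of what the source reports. "The series", "measured", "known", "first", "only" and "open" are said of these compounds alone.

Going by the values given here, compound 3 `CCCN(CCC)c1c(C)nc2c(OCc3ccccc3)cccn12` gives 60% in a functional assay on the whole organism with Rattus norvegicus as the target, at a dose of 40 mg/kg by the intraperitoneal route (on this read-out higher numbers stand for more inhibition at the one dose given (going by the name of the read-out) and lower numbers for less inhibition), the lowest of the three numbers measured so far. Compound 1 `CC(=O)Nc1c(C)nc2c(OCc3ccccc3)cccn12` gives 93% and compound 2 `CCCNc1c(C)nc2c(OCc3ccccc3)cccn12` gives 99%. Compound 4 `COc1c(C)nc2c(OCc3ccccc3)cccn12` differs from compound 3 by methoxy in place of dipropylamino on an aromatic carbon. Among the compounds with values here, two measured steps bear on this change: a number 39 percentage points lower from compound 2 to compound 3 (beyond the scatter) and a number 33 percentage points lower from compound 1 to compound 3 (beyond the scatter), both large falls once the nitrogen carried two propyl groups, whereas a number 6 percentage points higher from compound 1 to compound 2 (within the scatter) stayed within the scatter. Within the data shown here, since the only large steps seen were these falls from compound 1 and compound 2 to compound 3, removing the dipropylamino in favour of the two-atom methoxy is expected to bring a large rise in this assay. Compound 4 is therefore estimated at 85%, between 60% and 100%, an expected step of a number 25 percentage points higher from compound 3 to compound 4 (beyond the scatter).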

Compound 4, a percentage reported as inhibition, in the whole organism at one dose (the size of the read-out at that dose, not a potency): 49%
Beside the measured number, compound 4's estimate is 36 percentage points above it, and the stated range ends above it.
By their numbers in this assay, from the lowest: compound 4; then compound 3; then compounds 1 and 2 (each within the scatter of the next).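

In this assay, methoxy in place of dipropylamino on this aromatic carbon brings a number 11 percentage points lower from compound 3 to compound 4 (beyond the scatter) rather than a recovery of inhibition. Against the two groups whose nitrogen keeps a hydrogen, the change brings the larger falls of a number 50 percentage points lower from compound 2 to compound 4 (beyond the scatter) and a number 44 percentage points lower from compound 1 to compound 4 (beyond the scatter) at this position. All three nitrogen-linked groups therefore stand above methoxy, and the size of the group alone does not set the order of these four compounds. No available evidence bears on what lies behind this result. Still open, going by these compounds, is whether a plain amino group, a hydroxyl or a longer chain such as butylamino would hold inhibition at this position.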